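The source may hold more compounds than are shown below. What is called first, only, known or untested is meant among the compounds shown, and "the series" means these compounds.

Measured compounds in a functional assay on KB cells (Homo sapiens) for inhibition; a higher number here means a weaker inhibitor, a lower number a stronger inhibitor:
Compound 1 `CCOC(=O)c1nc([C@@H]2O[C@H](CO)[C@@H](O)[C@H]2O)c(N)nc1Cl` gives > 100000 nM, a limit of the assay rather than a number.
Compound 2 `NC(=O)c1nc([C@@H]2O[C@H](CO)[C@@H](O)[C@H]2O)c(N)nc1Cl` gives > 100000 nM, likewise a limit.
Compound 3 `COc1nc(Cl)c(C(N)=O)nc1[C@@H]1O[C@H](CO)[C@@H](O)[C@H]1O` gives > 100000 nM, again a limit.

Compound 3 therefore stands nowhere on a scale of numbers in this assay: it sits at a limit, and so do the two other values shown, which is the whole of the evidence here (the limit of > 100000 nM in this assay, at which 3 of the 3 values shown sit). The two measured steps, a step that the two limits leave unreadable from compound 1 to compound 2 and a step that the two limits leave unreadable from compound 2 to compound 3, are both unreadable, since each connects two limits; neither their size nor their direction can be taken from the data.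

Compound 4 `CCOc1nc(Cl)c(C(N)=O)nc1[C@@H]1O[C@H](CO)[C@@H](O)[C@H]1O` differs from compound 3 by methyl in place of hydrogen on a saturated chain carbon bound to an oxygen on an aromatic ring. Among the compounds with values here, this change has no measured counterpart. The steps that might bear on it, amino in place of ethoxy on a carbonyl carbon and methoxy in place of amino on an aromatic carbon, give no readable size, so nothing in the set points toward any step beyond the scatter for this homologation.

Compound 3 shows only the limit > 100000 nM.
Compound 4 is expected to remain at the limit as well, estimated at 200000 nM, with a range from 50000 nM to 1000000 nM.
The step that the limit leaves unreadable from compound 3 to compound 4 is expected to lie within the scatter, with no direction claimed.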

Compound 4, half-maximal inhibitory concentration: > 100000 nM
Compound 4: no number, only a limit (the forecaster's own chance of this, stated with the estimate: 90%); the middle value lies beyond the limit too.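

In this assay compound 4 gives > 100000 nM, a limit and not a number. No new step can be read from compound 3 or compound 2 to compound 4, as each pair joins two limits: the limit of > 100000 nM in this assay, at which 4 of the 4 values shown sit.

The compounds shown leave open whether methoxy to ethoxy, or any other change among them, alters inhibition in this assay.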